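The source may report more compounds than this note shows. Statements on the series, on what has been measured and on what is new or still open speak of the compounds shown alone.

Compound 1 `CCc1cc(-c2noc(-c3cc(C)nc(CN(C)CC(C)C)c3)n2)cc(C)c1OC[C@@H](O)CNC(=O)CO` gives 197 mL.min-1.g-1 in an ADME assay on liver (strain Wistar) for metabolic stability, with Liver microsome (Rattus norvegicus) as the target, read by LC-MS, using microsomes and NADPH, with a stated time of 15 min, tested at 1 uM; on this read-out lower numbers stand for slow clearance and higher numbers for fast clearance.
Compound 2 `CCc1cc(-c2noc(-c3cc(C)cc(CN(C)C)c3)n2)cc(C)c1OC[C@@H](O)CNC(=O)CO` gives > 1250 mL.min-1.g-1, which is a limit of the assay and not a number.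
Compound 3 `CCc1cc(-c2noc(-c3cc(C)cc(CN(C)CC(C)C)c3)n2)cc(C)c1OC[C@@H](O)CNC(=O)CO` gives 20 mL.min-1.g-1.

Compound 2 stands at the limit of > 1250 mL.min-1.g-1 in this assay, at which 1 of the 3 values shown sits, so its clearance is known only as a limit. Compound 4 `CCc1cc(-c2nc(-c3cc(C)c(OC[C@@H](O)CNC(=O)CO)c(CC)c3)no2)ccc1CN(C)C` is not yet measured. It differs from compound 2 by 4-((dimethylamino)methyl)-3-ethylphenyl in place of 3-((dimethylamino)methyl)-5-methylphenyl on an aromatic carbon.

Only one step has been measured among these compounds: an at least 62-fold lower number from compound 2 to compound 3 (1.79 log units; beyond the scatter). That step concerns an isopropyl added on a saturated chain carbon bound to an amine nitrogen, whereas the change to compound 4 leaves the dimethylaminomethyl group in place and alters the pattern of the aromatic ring. Within the data shown here, no measured step therefore bears directly on the move from compound 2 to compound 4, and compound 2 itself offers only a limit as a starting point. Compound 4 is expected to remain in the fast-clearance region, with the step estimated as an at least 1.3-fold lower number from compound 2 to compound 4 (0.14 log units; that floor lies within the scatter). Compound 4 is thus estimated at 900 mL.min-1.g-1, between 300 mL.min-1.g-1 and 1250 mL.min-1.g-1.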

Compound 4, intrinsic clearance in microsomes: 1010 mL.min-1.g-1
For compound 4 the middle estimate is 1.1-fold (0.05 log units) below the measured one, within the range that was stated.
By their numbers in this assay, from the lowest: compound 3; then compound 1; then compound 4. At a limit, above all of these: compound 2.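

With 4-((dimethylamino)methyl)-3-ethylphenyl in place of 3-((dimethylamino)methyl)-5-methylphenyl on this aromatic carbon, the dimethylaminomethyl group now comes with a measured number, and in this assay compound 4 gives 1010 mL.min-1.g-1, still a high number on this read-out. The change can only be read as an at least 1.2-fold lower number from compound 2 to compound 4 (0.09 log units; that floor lies within the scatter), so the data show no shift beyond the scatter, though they do not fix the true size of the step. Compound 2 is known only as a limit: the limit of > 1250 mL.min-1.g-1 in this assay, at which 1 of the 4 values shown sits.

The compounds shown do not separate the swap of methyl for ethyl from the new ring pattern, and they leave open how the 4-substituted arrangement would read with the larger amine of compound 3. Also open, going by these compounds, is how a morpholine in place of the dimethylamino group would read on this aryl ring.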